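Compound 3 to compound 4: methoxycarbonyl enters

The compounds below may be only part of what the source reports. "The series", "measured", "known", "first", "only" and "open" are said of these compounds alone.

In a functional assay on CCRF-CEM cells (Homo sapiens) for cytotoxicity, in the presence of a further agent that is not named here (on this read-out higher numbers stand for weaker inhibition and lower numbers for stronger inhibition), compound 3 (`Nc1nc(N)c(CCCN(Cc2ccc(NC(CCC(=O)O)C(=O)O)cc2)c2ccc([N+](=O)[O-])c(F)c2F)c(O)n1`) reads > 100000 nM as a limit of the assay and not a number. Compound 1 (`COC(=O)c1ccc(CN(CCCc2c(N)nc(N)nc2O)c2cc(F)cc(F)c2[N+](=O)[O-])cc1`) reads > 100000 nM as a limit as well. Among the measured compounds shown here, compound 2 (`COC(=O)c1ccc(CN(CCCc2c(N)nc(N)nc2O)c2cc(F)c(F)cc2[N+](=O)[O-])cc1`) gives 53000 nM as the only actual number so far. From the compounds shown here alone, compound 3 therefore stands at the limit of > 100000 nM in this assay, at which 2 of the 3 values shown sit, and its true value remains unknown.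

Compound 4 (`COC(=O)c1ccc(CN(CCCc2c(N)nc(N)nc2O)c2ccc([N+](=O)[O-])c(F)c2F)cc1`) has methoxycarbonyl in place of (1,3-dicarboxypropyl)amino on an aromatic carbon. For the measured compounds named here, no measured step covers this change. Going by the values given here, the only step available is an at least 1.8-fold lower number from compound 1 to compound 2 (0.27 log units; that floor lies within the scatter) and it concerns a different part of the structure, with a floor inside the scatter. Compound 2 at 53000 nM carries the same methoxycarbonyl as compound 4, so a modestly lower number than the reading of compound 3 is expected. The estimated step runs an at least 1.6-fold lower number from compound 3 to compound 4 (0.22 log units; that floor lies within the scatter) and is expected to be small. For compound 4 the estimate is 60000 nM with an expected range of 20000 nM to 150000 nM and another limit reading remains quite possible.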

Compound 4, half-maximal inhibitory concentration: 45000 nM
Compound 4: middle estimate off by 1.3-fold (0.12 log units), on the high side, and the stated range covers the measured number.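

In this assay the reading of compound 3 is a limit and not a number, so any step from it is only a floor: the limit of > 100000 nM in this assay, at which 2 of the 4 values shown sit.

Methoxycarbonyl in place of (1,3-dicarboxypropyl)amino on this aromatic carbon brings the reading into the measurable range, with an at least 2.2-fold lower number from compound 3 to compound 4 (0.34 log units; beyond the scatter), the only step at this position so far and one that clears the scatter. With methoxycarbonyl held constant, the nitrophenyl pattern separates only in part: an at least 2.2-fold lower number from compound 1 to compound 4 (0.34 log units; beyond the scatter), whereas a 1.2-fold lower number from compound 2 to compound 4 (0.07 log units; within the scatter), so the 2,3-difluoro-4-nitrophenyl and 4,5-difluoro-2-nitrophenyl compounds cannot be ranked.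

From the compounds shown here alone, the true size of both floors stays open. The compounds shown also leave open how a nitrile or a primary amide would read in place of methoxycarbonyl on that aromatic carbon.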